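Notes on the shared core: pyridylmethyl to bromobenzyl

The source may report more compounds than this note shows. Statements on the series, on what has been measured and on what is new or still open speak of the compounds shown alone.

Three compounds of the shared core carry the arylsulfamate and differ in the arm on the aromatic amine. Compound 1 `CCN(Cc1ccc(Br)cc1)c1ccc(C(=O)N2CCc3ccc(OS(N)(=O)=O)cc3C2)cc1` gives the highest number in an assay on HEK293 cells for inhibition of Steryl-sulfatase (Homo sapiens), tested at 1 uM (a lower number here means a weaker effect, a higher number a stronger effect of the compound at the concentration tested), at 95.9%. Compound 2 `CCN(Cc1ccccc1)Cc1ccc(S(=O)(=O)N2CCc3ccc(OS(N)(=O)=O)cc3C2)cc1` gives 31% in this assay. Compound 3 `CCN(Cc1ccncc1)c1cccc(C(=O)N2CCc3ccc(OS(N)(=O)=O)cc3C2)c1` gives 52.8% in this assay, second highest of the three, a number beyond the scatter below compound 1 and beyond the scatter above compound 2. No pair among these three differs in only one place, so no single step can be read from them.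

Compound 4 `CCN(Cc1cccc(Br)c1)c1cccc(C(=O)N2CCc3ccc(OS(N)(=O)=O)cc3C2)c1` is the untested partner of compound 3. It differs by 3-bromophenyl in place of pyridin-4-yl on a saturated chain carbon bound to a nitrogen on an aromatic ring.

Compound 1 also carries a bromobenzyl and gives 95.9%, but it differs from compound 4 in more than one place, so it shows only what a bromobenzyl analogue of this core can reach. The step from compound 3 to compound 4 is expected to be an increase beyond the scatter, a number 21.2 percentage points higher from compound 3 to compound 4 (beyond the scatter). Compound 4 is therefore estimated at 74% in this assay, with a range from 50% to 93%.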

Compound 4, a percentage reported as inhibition, at one concentration (the size of the read-out at that concentration, not a potency): 24.9%
Compound 4: the middle estimate sits 49.1 percentage points above what was measured, outside the stated range (below it).
By their numbers in this assay, from the lowest: compounds 4 and 2 (each within the scatter of the next); then compound 3; then compound 1.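

Among these compounds, the first single-place step, 3-bromophenyl in place of pyridin-4-yl on a saturated chain carbon bound to a nitrogen on an aromatic ring, gives in this assay a number 27.9 percentage points lower from compound 3 to compound 4 (beyond the scatter). The read-out is therefore sensitive to the change at this position, and on the core of compound 3 a 3-bromobenzyl arm does not bring a high number. Nothing at hand explains the drop.

The step swaps the ring nitrogen for a carbon and adds the bromine at once, so a plain phenyl or a pyridin-3-yl in the same place would be needed to tell these two parts apart. On these data alone, whether the step carries over to the core of compound 1 also remains open.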